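This account rests on a few compounds, and the source may have more. Where it says the series, first, only, none or still open, it means among the compounds named here.

Measured compounds so far:
Compound 1 `Nc1ccc2nc(N)sc2c1` shows only > 10 mg/kg in a functional assay on the whole organism with Rattus norvegicus as the target (on this read-out higher numbers stand for an effect only at larger amounts of compound and lower numbers for an effect already at smaller amounts), which is a limit of the assay and not a number.
Compound 2 `Nc1nc2ccc(C(F)(F)C(F)(F)F)cc2s1` gives 2.5 mg/kg in this assay.
Compound 3 `N=c1sc2cc(OC(F)(F)F)ccc2n1CCS(N)(=O)=O` gives 6 mg/kg in this assay.

Of the two values that are actual numbers, compound 3 stands highest, that is, it needs the larger dose; compound 2 lies below it by a gap beyond the usual scatter. Compound 1 sits at the limit of > 10 mg/kg in this assay, at which 1 of the 3 values shown sits.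

Compound 4 `CN(C)CCn1c(=N)sc2cc(OC(F)(F)F)ccc21` has not yet been measured. It differs from compound 3 in a single place: dimethylamino in place of sulfamoyl on a saturated chain carbon, two bonds along the chain from an aromatic nitrogen. Going by the values given here, no measured pair of compounds shows this kind of change, so nothing here tells how large a shift such an exchange brings. The expectation therefore rests on compound 3 alone, with a step of a 1.5-fold lower number from compound 3 to compound 4 (0.18 log units; within the scatter) in this assay that is expected to stay near the scatter, leaning, if anywhere, toward a somewhat lower number. On that basis compound 4 is estimated at 4 mg/kg, within a range from 1.5 mg/kg to 10 mg/kg.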

Compound 4, dose for half-maximal effect: 2.3 mg/kg
Estimate against measurement, compound 4: 1.7-fold (0.24 log units) above; measured number inside the range.
By their numbers in this assay, from the lowest: compounds 4 and 2 (each within the scatter of the next); then compound 3. At a limit, above all of these: compound 1.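

Exchanging sulfamoyl for dimethylamino on a saturated chain carbon, two bonds along the chain from an aromatic nitrogen, gives a 2.6-fold lower number from compound 3 to compound 4 (0.42 log units; beyond the scatter) in this assay, the first step measured at this place. The end of this side chain therefore affects the dose needed, and the effect in the whole animal does not depend on keeping sulfamoyl there, since the dimethylamino compound needs the smaller dose. Going by these compounds alone, nothing measured so far explains why this exchange lowers the number.

One exchange cannot separate what dimethylamino adds from what the loss of sulfamoyl removes. A primary amine, a carboxylic acid or a longer chain carrying the dimethylamino group at this place would show whether the trend extends to other end groups or chain lengths, and how much of the shift belongs to dimethylamino itself.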